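A few compounds are considered here, and "the series" means these few. Any claim that something is new, unique, unknown or untested is made for them only; others in the source may bear on it.

Of the compounds shown here, three built on one shared core have been measured in an ADME assay on 184B5 cells (Homo sapiens) for cytotoxicity, read by sulforhodamine B assay, with a stated time of 48 h; on this read-out higher numbers stand for weaker inhibition of growth and lower numbers for stronger inhibition of growth. Compound 1 `CCN(CC)CN1C(=O)/C(=N\c2nc3ccc(C)cc3s2)c2c(Br)cccc21` gives 34300 nM, compound 2 `Cc1ccc2nc(/N=C3\C(=O)N(CN4CCCCC4)c4ccccc43)sc2c1` gives 34900 nM, and compound 3 `Cc1ccc2nc(/N=C3\C(=O)N(CN(C)C)c4cccc(Br)c43)sc2c1` gives 74800 nM. Compound 3 thus stands at the highest number of the three, that is, it inhibits growth most weakly; compound 2 lies nearest to it, and compound 1 furthest, both being beyond the scatter. Among the measured compounds shown here, the single measured step that bears on the change considered here is a 2.2-fold higher number from compound 1 to compound 3 (0.34 log units; beyond the scatter), which shows that shrinking the amine at this position raised the number.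

Compound 4 `Cc1ccc2nc(/N=C3\C(=O)N(CN4CCCCC4)c4cccc(Br)c43)sc2c1` differs from compound 3 by piperidin-1-yl in place of dimethylamino on a saturated chain carbon bound to an amide-type nitrogen in a ring. This change moves in the opposite direction to the step from compound 1 to compound 3, enlarging the amine rather than shrinking it, and compound 2, which carries the same piperidin-1-yl group though without the bromine, sits at a clearly lower number than compound 3. A modest fall in this assay is therefore expected for compound 4, roughly undoing the earlier rise. The estimate for compound 4 in this assay is 38000 nM, with a likely range from 18000 nM to 80000 nM, which would mean a step of a 2.0-fold lower number from compound 3 to compound 4 (0.29 log units; within the scatter).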

Compound 4, concentration for 50% growth inhibition: 85200 nM
Compound 4: the middle estimate sits 2.2-fold (0.35 log units) below what was measured; the measured number lies above the stated range.
By their numbers in this assay, from the lowest: compounds 1 and 2 (each within the scatter of the next); then compounds 3 and 4 (each within the scatter of the next).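

In this assay, piperidin-1-yl in place of dimethylamino on a saturated chain carbon bound to an amide-type nitrogen in a ring gives a 1.1-fold higher number from compound 3 to compound 4 (0.06 log units; within the scatter) and so no real difference: with bromo on the core, these two amines cannot be told apart, although piperidin-1-yl brings a ring of its own and more heavy atoms. Diethylamino is the group that stands apart, since a 2.5-fold higher number from compound 1 to compound 4 (0.40 log units; beyond the scatter) is about as large as a 2.2-fold higher number from compound 1 to compound 3 (0.34 log units; beyond the scatter) and both lie beyond the scatter, so among these three amines the number does not simply follow the size of the group. The bromo group also gets its first one-place reading here: bromo in place of hydrogen on an aromatic carbon, with piperidin-1-yl kept, gives a 2.4-fold higher number from compound 2 to compound 4 (0.39 log units; beyond the scatter) as a modest rise in the number, which means weaker inhibition of growth.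

No measurement at hand explains why any of these numbers move. The compounds shown leave open whether the bromo step holds with dimethylamino or diethylamino in place of piperidin-1-yl, and whether a ring amine with an added oxygen, such as morpholin-4-yl, would read like piperidin-1-yl.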